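The compounds below may be only part of what the source reports. "The series", "measured", "known", "first", "only" and "open" are said of these compounds alone.

Among the measured compounds shown here, in a functional assay on MCF7 cells (Homo sapiens) for cytotoxicity, read by MTT assay, with a stated time of 72 h (a lower number here means a stronger inhibitor, a higher number a weaker inhibitor), compound 1 (`CNC(=O)c1cc(Oc2ccc(C(=O)/C=C/c3ccc(F)cc3Cl)cc2)ccn1`) gives 21100 nM and stands as the higher of the two numbers measured so far. Compound 2 (`CNC(=O)c1cc(Oc2ccc(/C=C/C(=O)c3ccc(Br)cc3)cc2)ccn1`) gives 7100 nM as the lower number, and the gap between them lies beyond the usual scatter. These two compounds differ in more than one place, so their gap cannot be tied to any single change. Compound 3 (`CNC(=O)c1cc(Oc2ccc(C(=O)/C=C/c3cccc([N+](=O)[O-])c3)cc2)ccn1`) keeps the core of compound 1 and carries 3-nitrophenyl in place of 2-chloro-4-fluorophenyl on a double-bonded chain carbon bound to a double-bonded chain carbon. For the measured compounds named here, no measured step between closely matched compounds speaks to this swap. Going by the values given here, compound 2 at 7100 nM shows only that a lower number is within reach for a close relative of compound 1, so a modest move downward is expected in this assay and it may not clear the scatter. Among the compounds with values here, the expected move, as an estimate, is a 1.8-fold lower number from compound 1 to compound 3 (0.25 log units; within the scatter) and no larger step is foreseen. Compound 3 is estimated at 12000 nM with an expected range from 5000 nM to 30000 nM around that figure.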

Compound 3, half-maximal inhibitory concentration: > 50000 nM
Compound 3: no number, only a limit; the forecaster's own chance of this, stated with the estimate: 10%; at least 4.1-fold (0.61 log units) between middle value and limit.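

Compound 3 has only a limit in this assay, > 50000 nM, and not a number. With 3-nitrophenyl in place of 2-chloro-4-fluorophenyl on a double-bonded chain carbon bound to a double-bonded chain carbon, the read-out gives an at least 2.3-fold higher number from compound 1 to compound 3 (0.37 log units; beyond the scatter), so this place on the shared core is shown to respond to a change of its aryl group, and in the direction of a weaker inhibitor, which the gap between compound 1 and compound 2 could not show with its several differences. The full size of this step cannot be read, and the step fixes only its direction and a lower bound: the limit of > 50000 nM in this assay, at which 1 of the 3 values shown sits.

The compounds shown leave open whether the change in compound 3 follows from losing the chlorine and fluorine or from gaining the nitro group, as both happen in this single step, and no cause for it can be drawn from them. They also leave open how an amine or a methoxy group would read in this assay if carried on the same phenyl ring in place of the nitro group.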